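Phenethylcarbonyl Replaces 4-Methylphenyl on Compound 3

The compounds below may be only part of what the source reports. "The series", "measured", "known", "first", "only" and "open" are said of these compounds alone.

Of the compounds shown here, three have been measured in a functional assay on cells (T-cell, Homo sapiens) for inhibition; on this read-out higher numbers stand for weaker inhibition and lower numbers for stronger inhibition. Compound 1 `COc1ccc(-c2cnc3nc(N)nc(NCc4ccccc4)c3n2)cc1OC` gives 13000 nM and compound 2 `CCOc1nc(N)nc2ncc(-c3ccc(C(F)(F)F)cc3)nc12` gives 10000 nM, while compound 3 `COc1ccc(-c2cnc3nc(N)nc(N4CCN(c5ccc(C)cc5)CC4)c3n2)cc1OC` gives 300 nM, the lowest of the three and beyond the scatter from both others, so compound 3 is the strongest inhibitor among them. Compound 4 `COc1ccc(-c2cnc3nc(N)nc(N4CCN(C(=O)CCc5ccccc5)CC4)c3n2)cc1OC` differs from compound 3 in one place: phenethylcarbonyl in place of 4-methylphenyl on an amine nitrogen in a ring. Going by the values given here, no measured pair shows this change, so its effect is unknown and a modest weakening is expected, a 2.7-fold higher number from compound 3 to compound 4 (0.43 log units; beyond the scatter), which stays beyond the scatter only slightly. Compound 4 is therefore expected to give about 800 nM in this assay, within a range from 200 nM to 4000 nM.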

Compound 4, half-maximal inhibitory concentration: 100 nM
Compound 4: the middle estimate sits 8.0-fold (0.90 log units) above what was measured; the whole stated range lies above it.
By their numbers in this assay, from the lowest: compound 4; then compound 3; then compounds 2 and 1 (each within the scatter of the next).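

Replacing 4-methylphenyl with phenethylcarbonyl on the amine nitrogen in the ring gives a 3.0-fold lower number from compound 3 to compound 4 (0.48 log units; beyond the scatter), so this place accepts a group with more heavy atoms and a carbonyl without any loss of inhibition. Both groups carry a six-membered aromatic ring of carbon only, so that ring alone does not separate compound 3 from compound 4. Nothing available bears on why the number falls.

As far as these compounds go, it remains open whether the carbonyl or the chain accounts for the step. An acetyl group, a benzoyl group or a longer chain on this nitrogen would begin to separate the two.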